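The source may report more compounds than this note shows. Statements on the series, on what has been measured and on what is new or still open speak of the compounds shown alone.

Compound 1 `Cc1cc(Nc2nc(NCc3ccccc3Cl)nc3[nH]ncc23)n[nH]1`: 4210 nM
Compound 2 `Cc1cc(Nc2nc(NCc3ccc(F)cc3)nc3[nH]ncc23)n[nH]1`: 8410 nM
Compound 3 `Cc1cc(Nc2nc(NCc3ccc(Cl)cc3)nc3[nH]ncc23)n[nH]1`: 7500 nM

In a functional assay on MDA-MB-231 cells (Homo sapiens) for inhibition, read by MTT assay, with a stated time of 5 days (on this read-out lower numbers stand for stronger inhibition and higher numbers for weaker inhibition), compound 3 gives 7500 nM, which lies within the scatter of both other compounds. The next compound, compound 4 `Cc1cc(Nc2nc(NCc3ccc(F)cc3F)nc3[nH]ncc23)n[nH]1`, has not been measured. It carries 2,4-difluorophenyl in place of 4-chlorophenyl on a saturated chain carbon bound to a nitrogen on an aromatic ring.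

Within the data shown here, three measured steps bear on this change. Swapping fluoro for chloro on an aromatic carbon gave a 1.1-fold lower number from compound 2 to compound 3 (0.05 log units; within the scatter). Changing the phenyl group gave a 2.0-fold higher number from compound 1 to compound 2 (0.30 log units; within the scatter) and a 1.8-fold higher number from compound 1 to compound 3 (0.25 log units; within the scatter). All three are small, so no step beyond the scatter is expected in this assay.

The estimated change is a 1.2-fold lower number from compound 3 to compound 4 (0.06 log units; within the scatter). For compound 4 the expected value is 6500 nM, with an estimated range of 3000 nM to 13000 nM.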

Compound 4, half-maximal inhibitory concentration: 2670 nM
Compound 4: middle estimate off by 2.4-fold (0.39 log units), on the high side; the measured number lies below the stated range.
By their numbers in this assay, from the lowest: compounds 4, 1, 3 and 2 (each within the scatter of the next, the first and the last beyond it).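

In this assay, this position gives its first steps beyond the scatter: 2,4-difluorophenyl in place of 4-chlorophenyl (a 2.8-fold lower number from compound 3 to compound 4 (0.45 log units; beyond the scatter)) and fluoro in place of hydrogen on an aromatic carbon (a 3.1-fold lower number from compound 2 to compound 4 (0.50 log units; beyond the scatter)). Against 2-chlorophenyl the change stays within the scatter (a 1.6-fold lower number from compound 1 to compound 4 (0.20 log units; within the scatter)), so the phenyl groups of compound 1 and compound 4 cannot be told apart here. Nothing available explains these steps. The compounds shown leave open how a methoxy group or an amine on the phenyl ring would read. On these data alone, a longer chain in place of the single saturated chain carbon also remains open.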